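The source may report more compounds than this note shows. Statements on the series, on what has been measured and on what is new or still open speak of the compounds shown alone.

Measured so far:
Compound 1 (`Clc1ccc(-c2cc(-c3cccs3)nc(-c3ccccc3Cl)c2)o1`) gives 17200 nM
Compound 2 (`Cc1ccc(-c2cc(-c3ccoc3)cc(-c3ccsc3)n2)cc1`) gives 47800 nM

In a functional assay on K562 cells (Homo sapiens) for cytotoxicity, in the presence of a further agent that is not named here (on this read-out higher numbers stand for weaker inhibition and lower numbers for stronger inhibition), compound 2, at 47800 nM, holds the higher of the two numbers, and the gap down to compound 1 lies beyond the scatter. Compound 3 (`Clc1ccc(-c2cc(-c3ccoc3)cc(-c3ccsc3)n2)cc1`) differs from compound 2 at one place, with chloro in place of methyl on an aromatic carbon, para to a large group (chloro in place of methyl on an aromatic carbon). This turns 4-methylphenyl into 4-chlorophenyl. For the measured compounds named here, no two measured compounds differ in one place only, so no direct step guides the expectation. Compound 1, which carries chloro, reads 17200 nM in this assay and offers only a weak hint toward lower numbers. The expected step of a 1.6-fold lower number from compound 2 to compound 3 (0.20 log units; within the scatter) is therefore small, toward stronger inhibition, and within the scatter. In this assay compound 3 is estimated at 30000 nM (expected range 12000 nM to 70000 nM).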

Compound 3, half-maximal inhibitory concentration: 730 nM
Compound 3: the middle estimate sits 41-fold (1.61 log units) above what was measured, outside the stated range (below it).
By their numbers in this assay, from the lowest: compound 3; then compound 1; then compound 2.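

In this assay, the position para to a large group on the six-membered aromatic ring of carbon only turns out to be highly sensitive: chloro in place of methyl gives a 65-fold lower number from compound 2 to compound 3 (1.82 log units; beyond the scatter), toward stronger inhibition, although neither group carries a ring, a hydrogen-bond donor or acceptor, or a net charge. For the compounds shown here, this is the first one-place comparison, so the size of a single change at this position can now be read directly, which the earlier pair of compounds, differing in several places, could not show. No measurement is available that explains the step.

From the compounds shown here alone, it remains open how other groups at this position, such as fluoro, methoxy or an amine, would read. Going by these compounds, it is also open whether the same change would have a similar effect on a different arrangement of the surrounding rings.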